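A few compounds are considered here, and "the series" means these few. Any claim that something is new, unique, unknown or untested is made for them only; others in the source may bear on it.

Measured so far:
Compound 1 `COc1c(C(=O)/C=C/c2ccc(Cl)cc2)c(O)c(Br)c2occc12` gives 3350 nM
Compound 2 `C=CCc1c(O)c(C(=O)/C=C/c2ccccc2)c(OC)c2ccoc12` gives 2800 nM

These two numbers come from a functional assay on CAKI-1 cells (Homo sapiens) for inhibition, with a stated time of 48 h (on this read-out higher numbers stand for weaker inhibition of growth and lower numbers for stronger inhibition of growth), and lie within the usual scatter of each other. Compound 2 therefore stands level with compound 1, and neither can be ranked over the other.

Compound 3 `C=CCc1c(O)c(C(=O)/C=C/c2ccc(Cl)cc2)c(OC)c2ccoc12` keeps the rest of compound 2 but goes from phenyl to 4-chlorophenyl. This puts chloro in place of hydrogen on an aromatic carbon, para to a large group (chloro in place of hydrogen on an aromatic carbon).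

For the measured compounds named here, no measured pair shows this change alone. Compound 1 also bears a 4-chlorophenyl group and gives 3350 nM in this assay while differing from compound 2 elsewhere too, and its number sits within the scatter of compound 2 at 2800 nM in the same test. That is weak evidence, but it offers no sign of a large shift. The estimated 1.1-fold lower number from compound 2 to compound 3 (0.05 log units; within the scatter) is expected to stay within the scatter, with no firm direction. The expected value for compound 3 is 2500 nM with an estimated range from 1000 nM to 6000 nM on this read-out.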

Compound 3, concentration for 50% growth inhibition: 2610 nM
The estimate for compound 3 lay 1.0-fold (0.02 log units) below the measured number; measured number inside the range.
By their numbers in this assay, from the lowest: compounds 3, 2 and 1 (each within the scatter of the next).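

Read in this assay the first direct pair for chloro in place of hydrogen on an aromatic carbon, para to a large group, gives a 1.1-fold lower number from compound 2 to compound 3 (0.03 log units; within the scatter) and so puts phenyl and 4-chlorophenyl level here, with this single swap leaving the read-out inside the usual scatter of repeat measurements. The second single-place pair, allyl in place of bromo on an aromatic carbon, gives a 1.3-fold lower number from compound 1 to compound 3 (0.11 log units; within the scatter) and so shows that these two groups cannot be told apart at that place either, which leaves all three compounds level with one another. Nothing reported for these compounds explains why their numbers stay so close together.

As far as these compounds go, it remains open whether an amine or a carboxylic acid in place of the chloro, on the same aromatic carbon, would carry the number beyond the scatter. From the compounds shown here alone, it is equally open whether a longer chain in place of the allyl group would separate itself from compound 3 in this assay when the rest of the structure stays the same.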